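Aryl sulfone change at compound 4: chloro to methyl

This account rests on a few compounds, and the source may have more. Where it says the series, first, only, none or still open, it means among the compounds named here.

Measured so far in an assay on isolated protein for displacement of a labelled ligand from metabotropic glutamate receptor 5 (Homo sapiens), with a stated time of 60 min, tested at 1 uM; on this read-out higher numbers stand for more inhibition at the one concentration tested (going by the name of the read-out) and lower numbers for less inhibition:
compound 1, `CC1CCN(c2c(S(=O)(=O)c3cc(F)cc(F)c3)cnc3cc(Cl)ccc23)CC1`, gives 94%
compound 2, `Cc1ccc(S(=O)(=O)c2cnc3cc(Cl)ccc3c2N2CCC(C)CC2)cc1`, gives 94%
compound 3, `CC1CCN(c2c(S(=O)(=O)c3ccc(Cl)c(Cl)c3)cnc3cc(Cl)ccc23)CC1`, gives 89%

All three share the same core and differ only in the aryl group on the sulfonyl sulfur. Compound 3 carries the smallest number of the three, but its distance to the others is within the scatter: a number 5 percentage points lower from compound 1 to compound 3 (within the scatter) and a number 5 percentage points lower from compound 2 to compound 3 (within the scatter). Likewise no change at the digits printed from compound 1 to compound 2 (within the scatter). On these numbers the aryl variations tried so far are indistinguishable in this assay.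

Compound 4, `Cc1ccc(S(=O)(=O)c2cnc3cc(Cl)ccc3c2N2CCC(C)CC2)cc1Cl`, is not yet measured. Its change from compound 3 is methyl in place of chloro on an aromatic carbon.

Within the data shown here, the step that bears on it most directly is the one from compound 2 to compound 3, where 3,4-dichlorophenyl replaced 4-methylphenyl: a number 5 percentage points lower from compound 2 to compound 3 (within the scatter). Compound 4 stands between those two aryl groups, keeping one chloro and taking back the methyl. Since that step, and the other two steps in the set, stayed inside the scatter, no step beyond the scatter is expected here either: a number 3 percentage points higher from compound 3 to compound 4 (within the scatter). Compound 4 is therefore estimated at 92%, in the range 82% to 98%.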

Compound 4, a percentage reported as inhibition, at one concentration (the size of the read-out at that concentration, not a potency): 89%
Estimate against measurement, compound 4: 3 percentage points above, and the stated range covers the measured number.
By their numbers in this assay, from the lowest: compounds 3, 4, 1 and 2 (each within the scatter of the next).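

Methyl in place of chloro on the aromatic carbon para to a large group and ortho to a chloro group gives no change at the digits printed from compound 3 to compound 4 (within the scatter) in this assay, the first exchange in the series confined to this one substituent rather than the whole aryl group. Compound 4 also allows the chloro itself to be read alone, as chloro in place of hydrogen on an aromatic carbon gives a number 5 percentage points lower from compound 2 to compound 4 (within the scatter), while the wider aryl exchange gives a number 5 percentage points lower from compound 1 to compound 4 (within the scatter), so neither the single-substituent changes nor the whole-group change separates these compounds on this read-out. No supporting data accompany these numbers that could account for the result.

All four values are readings at one concentration and not potencies, leaving open whether these aryl groups would differ in a full concentration-response measurement. Also open, going by these compounds, is whether a group of a different kind on this aromatic carbon, such as an amine, a carboxylic acid or a longer alkyl chain, would give a step beyond the scatter.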